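Fluoro to Chloro on the Aryl Ring: Expected Step

A few compounds are considered here, and "the series" means these few. Any claim that something is new, unique, unknown or untested is made for them only; others in the source may bear on it.

Of the compounds shown here, two have so far been measured in a functional assay on MCF7 cells (Homo sapiens) for cytotoxicity, read by CCK-8 assay, with a stated time of 24 h; on this read-out higher numbers stand for weaker inhibition and lower numbers for stronger inhibition. Compound 1 `C/C(=C\c1cc(-c2ccc(F)cc2)cs1)C(N)=O` gives 1440 nM in this assay. Compound 2 `C/C(=C\c1cccc(-c2ccccc2)c1)C(N)=O` gives 6540 nM in this assay. Compound 1 thus stands with the lower of the two numbers, and its gap to compound 2 lies beyond the usual scatter of repeated measurements, so compound 1 is the stronger inhibitor of this pair.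

Compound 3 `C/C(=C\c1cc(-c2ccc(Cl)cc2)cs1)C(N)=O` has not yet been measured in this assay. It differs from compound 1 in one place only: chloro in place of fluoro on an aromatic carbon, in words chloro in place of fluoro on an aromatic carbon. Going by the values given here, no measured pair here shows this same exchange, so nothing in the numbers tells how large such a step is. The exchange swaps a single heavy atom for another, leaving hydrogen-bond donors, hydrogen-bond acceptors and charge unchanged, and the step from compound 1 to compound 3 is expected to be a 1.2-fold lower number from compound 1 to compound 3 (0.08 log units; within the scatter), not beyond the scatter in either direction. Compound 3 is therefore estimated to give about 1200 nM in this assay, with a likely range from 450 nM to 3200 nM.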

Compound 3, half-maximal inhibitory concentration: 17100 nM
The estimate for compound 3 lay 14-fold (1.15 log units) below the measured number; the measured number lies above the stated range.
By their numbers in this assay, from the lowest: compound 1; then compound 2; then compound 3.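

In this assay, chloro in place of fluoro on an aromatic carbon, para to a large group, brings a 12-fold higher number from compound 1 to compound 3 (1.07 log units; beyond the scatter) and so a large loss of strength from the exchange of a single heavy atom. The two halogens are thus not interchangeable at this position on the core of compound 1, even though hydrogen-bond donors, hydrogen-bond acceptors and net charge are the same in compound 1 and compound 3. Nothing available here accounts for the size of this step, so it stands as an observation without an explanation.

As far as these compounds go, it remains open whether fluoro at this position helps or chloro harms, and a plain hydrogen, a methyl or a nitrile in the same place could begin to separate these two readings. It also remains open whether the same exchange would bring a step of similar size on another core, as this single pair is the only case of it shown here.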